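Heteroaryl exchange on the shared core: compound 3 to compound 4

This account rests on a few compounds, and the source may have more. Where it says the series, first, only, none or still open, it means among the compounds named here.

Of the compounds shown here, three sharing one core have been measured in a functional assay with Alpha-1A adrenergic receptor (Homo sapiens) as the target, read by calcium flux; a lower number here means a smaller maximal response, a higher number a larger maximal response. Compound 1 `c1coc(-c2ccccc2OCC2=NCCN2)c1` gives 106%, compound 2 `c1ccc(-c2ccoc2)c(OCC2=NCCN2)c1` gives 104%, and compound 3 `c1ccc(-c2ccsc2)c(OCC2=NCCN2)c1` gives 98%. The three single-point exchanges between them all stay within the scatter: a number 2 percentage points lower from compound 1 to compound 2 (within the scatter), a number 8 percentage points lower from compound 1 to compound 3 (within the scatter), a number 6 percentage points lower from compound 2 to compound 3 (within the scatter). On the numbers shown compound 3 stands at the low end of the three, yet separated from both neighbours only within the scatter.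

Compound 4 `c1ccc(-c2cc[nH]n2)c(OCC2=NCCN2)c1` has not yet been measured in this assay. It differs from compound 3 in one place: 1H-pyrazol-3-yl in place of thiophen-3-yl on an aromatic carbon. Among the measured compounds shown here, the steps that bear on this are the three heteroaryl exchanges already seen, each within the scatter; none of them, however, brought in a hydrogen-bond donor, so the present change has no exact precedent. On the evidence of those exchanges the expected step in this assay is a number 1 percentage points lower from compound 3 to compound 4 (within the scatter), that is none beyond the scatter. Compound 4 is therefore estimated at 97%, within 82% to 112%.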

Compound 4, largest response reached (reported as maximum), in percent of the reference or control that the assay uses: 119%
The estimate for compound 4 lay 22 percentage points below the measured number; the measured number lies above the stated range.
By their numbers in this assay, from the lowest: compounds 3, 2 and 1 (each within the scatter of the next); then compound 4.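

In this assay, the aromatic carbon that tolerated exchange among furan-2-yl, furan-3-yl and thiophen-3-yl responds to 1H-pyrazol-3-yl, with a number 21 percentage points higher from compound 3 to compound 4 (beyond the scatter), a number 15 percentage points higher from compound 2 to compound 4 (beyond the scatter) and a number 13 percentage points higher from compound 1 to compound 4 (beyond the scatter). Of the groups compared, 1H-pyrazol-3-yl alone carries 1 hydrogen-bond donor, but this single example cannot separate the donor from the ring's 2 hetero atoms, both nitrogen. Nothing available accounts for the rise in maximal response.

Going by these compounds, it remains open whether the ring hydrogen on nitrogen is what counts, and a 1-methylpyrazol-3-yl group on the same carbon would put that to the test. Also open, on these data alone, is whether a non-ring amine, such as aminomethyl, or an imidazolyl ring would give a similar step.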